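Pyrazolyl enones: aryl ketone swap in ACHN cytotoxicity

The compounds below may be only part of what the source reports. "The series", "measured", "known", "first", "only" and "open" are said of these compounds alone.

Measured compounds:
compound 1 `COc1cc(-c2cc(/C=C/C(=O)c3ccc(N)cc3)[nH]n2)cc(OC)c1OC` — 79%
compound 2 `COc1ccc(-c2cc(/C=C/C(=O)c3ccc(OC)c(OC)c3)[nH]n2)cc1` — 82%
compound 3 `COc1ccc(-c2cc(/C=C/C(=O)c3cc(OC)c(OC)c(OC)c3)[nH]n2)cc1OC` — 78%

In a functional assay on ACHN cells (Homo sapiens) for cytotoxicity, read by sulforhodamine B assay, with a stated time of 48 h, tested at 1 uM (a lower number here means a stronger effect, a higher number a weaker effect of the compound at the concentration tested), compound 1 gives 79%. Within the data shown here, its value sits within the scatter of both compound 2 and compound 3, so the three numbers cannot be told apart; no step between measured compounds is available.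

Compound 4 `COc1cc(-c2cc(/C=C/C(=O)c3ccc(F)c(F)c3)[nH]n2)cc(OC)c1OC` differs from compound 1 in one place: 3,4-difluorophenyl in place of 4-aminophenyl on a carbonyl carbon. Since the three measured compounds, which differ in the pattern of groups on both aryl rings, all land together, no step beyond the scatter is expected in this assay for the change to compound 4. Compound 4 is therefore estimated at 80%, within 68% to 92%, an expected step of a number 1 percentage points higher from compound 1 to compound 4 (within the scatter).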

Compound 4, a percentage reported as activity, at one concentration (the size of the read-out at that concentration, not a potency): 100%
Beside the measured number, compound 4's estimate is 20 percentage points below it, and the stated range ends below it.
By their numbers in this assay, from the lowest: compounds 3, 1 and 2 (each within the scatter of the next); then compound 4.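

In this assay, among these compounds, the earlier compounds gave no readable step, whereas the aryl group on the carbonyl carbon now moves the read-out: 3,4-difluorophenyl in place of 4-aminophenyl gives a number 21 percentage points higher from compound 1 to compound 4 (beyond the scatter) and so a weaker effect at the concentration tested. The position is therefore not indifferent to this change on the core of compound 1. No measurement available here accounts for the step.

On these data alone, it remains open whether the step follows from the loss of 4-aminophenyl or from the entry of 3,4-difluorophenyl. Plain phenyl or 4-hydroxyphenyl at the same carbonyl carbon would help separate the two.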